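Compound 3: trifluoromethyl in place of methyl

The source may hold more compounds than are shown below. What is called first, only, known or untested is meant among the compounds shown, and "the series" means these compounds.

Compound 1 (`Cc1ccc([C@H](C)NC(=O)Cn2nnc3ccccc3c2=O)cc1`) gives < 9.9 mL/min/kg in an ADME assay on microsomes from liver (Homo sapiens) for metabolic stability (on this read-out higher numbers stand for fast clearance and lower numbers for slow clearance), which is a limit of the assay and not a number. Going by the values given here, compound 2 (`Cc1ccc([C@H](C)NC(=O)Cn2nnc3ccccc3c2=O)c(F)c1`) reads 28 mL/min/kg in this assay, the only true number so far. Among the compounds with values here, the one measured step is an at least 2.8-fold higher number from compound 1 to compound 2 (0.45 log units; beyond the scatter) and it belongs to a different change, so it sizes the next one only loosely. Compound 3 (`C[C@H](NC(=O)Cn1nnc2ccccc2c1=O)c1ccc(C(F)(F)F)cc1F`) carries trifluoromethyl in place of methyl on an aromatic carbon as trifluoromethyl in place of methyl on an aromatic carbon. Within the data shown here, a modest fall is expected, a 1.9-fold lower number from compound 2 to compound 3 (0.27 log units; within the scatter), though no measured step covers this change. For compound 3 the estimated clearance is 15 mL/min/kg, with an expected range of 7 mL/min/kg to 32 mL/min/kg.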

Compound 3, clearance: 17 mL/min/kg
Estimate against measurement, compound 3: 1.1-fold (0.05 log units) below; low and high end bracket the measured number.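

Going by these compounds alone, at this position, para to a large group and meta to a fluoro group, trifluoromethyl in place of methyl gives a 1.6-fold lower number from compound 2 to compound 3 (0.22 log units; within the scatter), the first step in this assay between two true numbers. The larger group therefore leaves clearance indistinguishable between these two compounds. Compound 1 remains a limit of the assay and not a number: the limit of < 9.9 mL/min/kg in this assay, at which 1 of the 3 values shown sits.

As far as these compounds go, what an amine, a nitrile or a methoxy group would read at this position stays open. Also open, from the compounds shown here alone, is whether trifluoromethyl would read the same on the core of compound 1, without the fluoro group.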